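Working notes: aryl change at the ring amide nitrogen

A few compounds are considered here, and "the series" means these few. Any claim that something is new, unique, unknown or untested is made for them only; others in the source may bear on it.

Measured compounds in a functional assay on MCF7 cells (Homo sapiens) for antiproliferative activity, read by MTT assay, with a stated time of 72 h; a lower number here means a stronger inhibitor, a higher number a weaker inhibitor:
compound 1 `Cc1ccc(N2C(=O)COc3ccc(-c4cnc5ccccc5c4)cc32)cc1` gives > 40000 nM, a limit of the assay.
compound 2 `O=C1COc2ccc(-c3cnc4ccccc4c3)cc2N1c1ccccc1` gives > 40000 nM, a limit of the assay.
compound 3 `O=C1COc2ccc(-c3cnc4ccccc4c3)cc2N1c1ccc(Cl)cc1` gives > 40000 nM, a limit of the assay.

Compound 3 stands at a limit of this assay rather than at a number, and the two further values shown are limits too; all three sit at one and the same point, (the limit of > 40000 nM in this assay, at which 3 of the 3 values shown sit). The steps among the measured compounds, a step that the two limits leave unreadable from compound 1 to compound 2, a step that the two limits leave unreadable from compound 1 to compound 3 and a step that the two limits leave unreadable from compound 2 to compound 3, therefore give neither a size nor a direction, and nothing can be said about how the three aryl groups on the ring amide nitrogen compare with one another.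

Compound 4 `COc1cccc(N2C(=O)COc3ccc(-c4cnc5ccccc5c4)cc32)c1` differs from compound 3 by 3-methoxyphenyl in place of 4-chlorophenyl on an amide-type nitrogen in a ring. It is the same position that varies among compounds 1, 2 and 3, and none of those variations produced a readable step. Within the data shown here, there is thus no measured step to carry over; the only guidance is that every group tried so far at this nitrogen leaves the compound at the limit. The step from compound 3 is accordingly expected to be a step that the limit leaves unreadable from compound 3 to compound 4, with compound 4 expected to remain at or near the limit. Compound 4 is estimated at 45000 nM, in a range from 12000 nM to 200000 nM, and this assay is expected most probably to report only a limit again.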

Compound 4, half-maximal inhibitory concentration: > 40000 nM
Compound 4: only a limit was reported; the forecaster's own chance of this, stated with the estimate: 80%; the middle value does not contradict the limit.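

In this assay compound 4 gives > 40000 nM, a limit of the assay. Its steps from compounds 1, 2 and 3 therefore cannot be read, in size or in direction: the limit of > 40000 nM in this assay, at which 4 of the 4 values shown sit.

The compounds shown leave open whether any aryl group on the ring amide nitrogen, or any change to the shared core, gives a measurable value in this assay.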